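The compounds below may be only part of what the source reports. "The series", "measured", "known", "first", "only" and "open" are said of these compounds alone.

In an assay on membranes from lung (Cavia porcellus) for binding affinity to leukotriene B4 receptor (Homo sapiens), read by radioligand binding (a lower number here means a stronger inhibitor, a higher number a weaker inhibitor), the three measured compounds stand as follows: compound 1 `CCc1cc(-c2ccc(F)cc2)c(O)cc1OCCCOc1ccccc1CCC(=O)O` gives 3.8 nM, compound 2 `CCc1cc(-c2ccc(F)cc2)c(O)cc1OCCCOc1cccc(CCCCC(=O)O)c1CCC(=O)O` gives 0.71 nM, and compound 3 `CCCc1c(OCCCOc2cc(O)c(-c3ccccc3)cc2CC)ccc2c1OC(C(=O)O)CC2` gives 2.8 nM.

Compound 1 has the highest number of the three. Compound 3 sits within the scatter of it, while compound 2 lies a 5.4-fold lower number from compound 1 to compound 2 (0.73 log units; beyond the scatter). Compound 4 `CCc1cc(-c2ccc(F)cc2)c(O)cc1OCCCOc1cccc(OC)c1CCC(=O)O` differs from compound 1 by methoxy in place of hydrogen on an aromatic carbon. For the measured compounds named here, the one measured step that bears on this position is the step from compound 1 to compound 2, a modest gain, made with a group that carries an acid; the entering methoxy is smaller, neutral and brings one hydrogen-bond acceptor, so a smaller step, if any, is expected. Compound 4 is therefore estimated at 2.5 nM, with a range of 1 nM to 6.5 nM, meaning an expected 1.5-fold lower number from compound 1 to compound 4 (0.18 log units; within the scatter).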

Compound 4, inhibition constant: 6.4 nM
Compound 4: middle estimate off by 2.6-fold (0.41 log units), on the low side, and the stated range covers the measured number.
By their numbers in this assay, from the lowest: compound 2; then compounds 3, 1 and 4 (each within the scatter of the next, the first and the last beyond it).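

In this assay, methoxy on this aromatic carbon, ortho to a 2-carboxyethyl group, leaves the number within the scatter (a 1.7-fold higher number from compound 1 to compound 4 (0.23 log units; within the scatter)). Putting methoxy in place of 4-carboxybutyl at the same carbon loses the gain of compound 2 (a 9.0-fold higher number from compound 2 to compound 4 (0.95 log units; beyond the scatter)), so that gain does not come with just any group here. Nothing in hand explains the difference between the two groups. Still open, from the compounds shown here alone, is whether the carboxylic acid or the chain length of 4-carboxybutyl carries the gain, which a plain butyl chain or a shorter carboxymethyl group at this carbon would help separate.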